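The compounds below may be only part of what the source reports. "The series", "measured", "known", "first", "only" and "open" are said of these compounds alone.

Measured in a functional assay on DU-145 cells (Homo sapiens) for antiproliferative activity, read by propidium iodide staining, with a stated time of 96 h; on this read-out higher numbers stand for weaker inhibition and lower numbers for stronger inhibition:
Compound 1 `CC(O)(CSc1cc(C(F)(F)F)cc(C(F)(F)F)c1)C(=O)Nc1ccc(S(F)(F)(F)(F)F)cc1`: 29700 nM
Compound 2 `CC(O)(CSc1ccccc1OC(F)(F)F)C(=O)Nc1cccc(S(F)(F)(F)(F)F)c1`: 17500 nM
Compound 3 `CC(O)(CS(=O)(=O)c1cccc(S(F)(F)(F)(F)F)c1)C(=O)Nc1cccc(S(F)(F)(F)(F)F)c1`: 29400 nM

These three compounds form a small set, and none separates clearly from the others. Compound 3, at 29400 nM, lies within the usual scatter of repeated measurements of both compound 1 and compound 2, so the numbers give no real ranking among them.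

The next compound to be tested is compound 4 `CC(O)(CS(=O)(=O)c1cccc(OC(F)(F)F)c1)C(=O)Nc1cccc(S(F)(F)(F)(F)F)c1`, which differs from compound 3 in one place: a group of 5 heavy atoms (1 carbon, 1 oxygen, 3 fluorine; no ring) in place of a group of 6 heavy atoms (5 fluorine, 1 sulfur; no ring), on an aromatic carbon. Trifluoromethoxy enters on an aromatic carbon of a six-membered aromatic ring of carbon only, meta to a large group, and the rest of the structure stays the same.

Among the compounds with values here, no two measured compounds differ by this swap alone, so the data offer no direct guide to its effect. The nearest hint is indirect: compound 2 also carries trifluoromethoxy, though it differs from compound 3 elsewhere too, and compound 2 gives 17500 nM. No shift beyond the scatter is therefore expected in this assay, in either direction. The expected change is a 1.2-fold lower number from compound 3 to compound 4 (0.07 log units; within the scatter). For compound 4 the estimated value is 25000 nM, with an expected range from 12000 nM to 50000 nM.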

Compound 4, half-maximal inhibitory concentration: 31500 nM
Compound 4: the middle estimate sits 1.3-fold (0.10 log units) below what was measured; the range from low to high includes it.
By their numbers in this assay, from the lowest: compounds 2, 3, 1 and 4 (each within the scatter of the next).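

In this assay, trifluoromethoxy in place of the group of 6 heavy atoms (5 fluorine, 1 sulfur), on an aromatic carbon of a six-membered aromatic ring of carbon only, meta to a large group, gives a 1.1-fold higher number from compound 3 to compound 4 (0.03 log units; within the scatter). Within the data shown here, this is the first comparison in the set that differs in one place only, and it shows that this position tolerates the swap with no change that can be told from the scatter, even though the entering group counts 1 hydrogen-bond acceptor and the leaving group 0. No measurement at hand offers an explanation for this result.

From the compounds shown here alone, it remains open whether any change at this position can move the number, since both groups here are large and fluorine-rich, and a very different group in the same place, such as an amine, a carboxylic acid or a plain methyl, could behave otherwise. Among these compounds, it is also open whether the same swap would be as uneventful at the second group of 6 heavy atoms, the one that compound 3 and compound 4 share on the other side of the core.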